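Methoxy to ethoxy on the shared core

A few compounds are considered here, and "the series" means these few. Any claim that something is new, unique, unknown or untested is made for them only; others in the source may bear on it.

For the measured compounds named here, compound 1 `CCCC1=C(OC)C(CCC)(CCC)C(=O)/C(=C(O)\C=C\c2ccccc2)C1=O` holds the higher of the two numbers so far in a functional assay on 1A9 cells (Homo sapiens) for antiproliferative activity, read by sulforhodamine B assay, with a stated time of 3 days; a higher number here means that more compound is needed for the effect, a lower number that less compound is needed: compound 1 gives 3.7 uM. Going by the values given here, compound 2 `CCCC1=C(OC)C(CCC)(CCC)C(=O)/C(=C(O)\C=C\c2ccc(I)cc2)C1=O` gives 1.8 uM in this assay, and the one measured step, a 2.1-fold lower number from compound 1 to compound 2 (0.31 log units; beyond the scatter), sits on the aromatic carbon and not on the side where compound 3 changes. Compound 3 `CCCC1=C(OCC)C(CCC)(CCC)C(=O)/C(=C(O)\C=C\c2ccccc2)C1=O` differs from compound 1 by methyl in place of hydrogen on a saturated chain carbon bound to an oxygen on an unsaturated carbon. Among the compounds with values here, no measured step touches the oxygen on an unsaturated carbon, so the direction of this change is not set by any recorded pair; the single step from compound 1 to compound 2 does not bear on it. For compound 3 the expectation is therefore no step beyond the scatter, with a wide range: compound 3 is estimated at 3.7 uM, between 1.5 uM and 9 uM, an expected step of no change at the digits printed from compound 1 to compound 3 (within the scatter).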

Compound 3, concentration for half-maximal effect: 4.3 uM
Beside the measured number, compound 3's estimate is 1.2-fold (0.07 log units) below it, within the range that was stated.
By their numbers in this assay, from the lowest: compound 2; then compounds 1 and 3 (each within the scatter of the next).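

In this assay, methoxy to ethoxy gives a 1.2-fold higher number from compound 1 to compound 3 (0.07 log units; within the scatter), so this position on the shared core takes one added methyl with no step beyond the scatter. For the compounds shown here, this is the first reading at the saturated chain carbon bound to an oxygen on an unsaturated carbon; the earlier step, a 2.1-fold lower number from compound 1 to compound 2 (0.31 log units; beyond the scatter), concerned only an aromatic carbon. No measured data on the compounds bear on why the number holds at this position.

One pair cannot show how far this tolerance extends: a longer chain such as propoxy or butoxy, or an amine carried on the oxygen, might behave differently. On these data alone, it also remains open whether the iodo group of compound 2 would give the same step on the ethoxy core.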